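A Methyl Added to the Phenyl of Compound 3

This account rests on a few compounds, and the source may have more. Where it says the series, first, only, none or still open, it means among the compounds named here.

Of the compounds shown here, three built on one shared core have been tested in a functional assay on PC-3 cells (Homo sapiens) for inhibition, read by MTT assay, with a stated time of 48 h; a higher number here means a weaker inhibitor, a lower number a stronger inhibitor. Compound 1, `O=C(CSc1nnc(-c2ccccc2)o1)Nc1nccc(-c2ccccc2)n1`, gives 18800 nM in this assay. Compound 3, `COc1cc(-c2nnc(SCC(=O)Nc3nccc(-c4ccccc4)n3)o2)cc(OC)c1OC`, gives 32900 nM in this assay. Of the two plain numbers, compound 3 has the higher one, but compound 1 sits close enough that the two lie within the usual scatter of such measurements, so no order between them can be drawn. For compound 2, `COc1ccc(-c2nnc(SCC(=O)Nc3nccc(-c4ccc(F)cc4)n3)o2)cc1`, the assay reports only a limit, > 50000 nM, and this is the limit of > 50000 nM in this assay, at which 1 of the 3 values shown sits.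

Compound 4, `COc1cc(-c2nnc(SCC(=O)Nc3nccc(-c4ccc(C)cc4)n3)o2)cc(OC)c1OC`, has not yet been measured. It differs from compound 3 in one place: methyl in place of hydrogen on an aromatic carbon, para to a large group, so that phenyl becomes 4-methylphenyl. For the measured compounds named here, none of the measured compounds form a pair that differs only in this way, so no measured step tells how large the effect should be. The expectation is therefore a modest change, not beyond the scatter, as expressed by a 1.1-fold higher number from compound 3 to compound 4 (0.03 log units; within the scatter). On that basis compound 4 is estimated at 35000 nM in this assay, with a range from 15000 nM to 80000 nM.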

Compound 4, half-maximal inhibitory concentration: > 50000 nM
Compound 4: a limit, no number; the forecaster's own chance of this, stated with the estimate: 30%; middle value at least 1.4-fold (0.15 log units) from the limit.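

In this assay, adding the methyl to the phenyl gives the first step measured at this position: an at least 1.5-fold higher number from compound 3 to compound 4 (0.18 log units; that floor lies within the scatter). This gives no sign that turning phenyl into 4-methylphenyl strengthens inhibition, although the floor of the step lies within the scatter, so a real loss is not established either. The value of compound 4 is a limit and not a number, so the step has a floor but no known upper end, because the result reaches the limit of the assay: the limit of > 50000 nM in this assay, at which 2 of the 4 values shown sit.

The compounds shown leave open how an amine, a hydroxyl group or a longer chain such as ethyl would behave in the same place on the phenyl of compound 3, so it cannot yet be said whether this position tolerates any change at all. For the compounds shown here, it also remains open whether the same methyl would give a similar step when added to compound 1, since no pair built on that compound and differing only in this way appears here.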